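This account rests on a few compounds, and the source may have more. Where it says the series, first, only, none or still open, it means among the compounds named here.

Compounds measured in an in vitro assay on CHO cells for displacement of a labelled ligand from Bombesin receptor subtype-3 (Homo sapiens), read by scintillation counting, with a stated time of 2 h; on this read-out higher numbers stand for weaker inhibition and lower numbers for stronger inhibition:

- compound 1 `CCC(C)(C)Cc1c[nH]c(CCc2ccc(-c3cccc(C)n3)cc2)n1`: 6.3 nM
- compound 2 `CCC(C)(C)Cc1c[nH]c(CCc2ccc(-c3ccncc3)cc2)n1`: 101 nM
- compound 3 `CCC(C)(C)Cc1c[nH]c(CCc2ccc(-c3csnn3)cc2)n1`: 45 nM

Compound 1 gives the lowest number of the three, and both steps away from it lie beyond the scatter: a 16-fold higher number from compound 1 to compound 2 (1.20 log units; beyond the scatter) and a 7.1-fold higher number from compound 1 to compound 3 (0.85 log units; beyond the scatter). Between the other two there is a further difference, a 2.2-fold lower number from compound 2 to compound 3 (0.35 log units; beyond the scatter).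

Compound 4 `CCC(C)(C)Cc1c[nH]c(CCc2ccc(-n3cncn3)cc2)n1` has not been measured. Its difference from compound 1 is 1H-1,2,4-triazol-1-yl in place of 6-methylpyridin-2-yl on an aromatic carbon.

Both measured steps from compound 1 bear on this change, since each replaces the 6-methylpyridin-2-yl with a different aromatic group on the same aromatic carbon. One of them, to pyridin-4-yl, is large; the other, to 1,2,3-thiadiazol-4-yl, is modest. Both go the same way, to a higher number in this assay. For compound 4 a step of similar kind is therefore expected, toward a higher number, of a size between the two measured ones; the expected step is a 9.5-fold higher number from compound 1 to compound 4 (0.98 log units; beyond the scatter). The estimate for compound 4 in this assay is 60 nM, with a range from 15 nM to 250 nM.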

Compound 4, half-maximal inhibitory concentration: 340 nM
Compound 4: middle estimate off by 5.7-fold (0.75 log units), on the low side, outside the stated range (above it).
By their numbers in this assay, from the lowest: compound 1; then compound 3; then compound 2; then compound 4.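

In this assay, 1H-1,2,4-triazol-1-yl gives the largest loss yet at this position, on an aromatic carbon para to a large group (a 54-fold higher number from compound 1 to compound 4 (1.73 log units; beyond the scatter)), and it also falls behind both earlier replacements (a 7.6-fold higher number from compound 3 to compound 4 (0.88 log units; beyond the scatter); a 3.4-fold higher number from compound 2 to compound 4 (0.53 log units; beyond the scatter)). The two earlier steps therefore did not mark the full extent of the loss here, and a five-membered aromatic ring does not by itself fix the outcome, since compound 3 and compound 4 both carry one yet remain apart. Nothing available bears on the origin of these differences.

A plain phenyl or an unsubstituted pyridin-2-yl at this place would show whether the methyl, the ring nitrogen or both set compound 1 apart. A methyl group on the triazole ring would show whether the methyl carries over to the five-membered rings.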